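A few compounds are considered here, and "the series" means these few. Any claim that something is new, unique, unknown or untested is made for them only; others in the source may bear on it.

Compound 1, `COc1cc(-c2cc(/C=C/C(=O)c3ccc(Cl)c(Cl)c3)[nH]n2)cc(OC)c1OC`: in a functional assay on UO-31 cells (Homo sapiens) for inhibition, read by sulforhodamine B assay, with a stated time of 48 h (on this read-out higher numbers stand for weaker inhibition of growth and lower numbers for stronger inhibition of growth), compound 1 gives only a limit, > 100000 nM, namely (the limit of > 100000 nM in this assay, at which 1 of the 3 values shown sits).
Compound 2, `COc1ccc(C(=O)/C=C/c2cc(-c3cc(OC)c(OC)c(OC)c3)n[nH]2)cc1OC`: in this assay compound 2 gives 2570 nM.
Compound 3, `COc1ccc(C(=O)/C=C/c2cc(-c3cc(OC)c(OC)c(OC)c3)n[nH]2)cc1`: in this assay compound 3 gives 2840 nM.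

Of the two actual numbers, compound 3 stands highest, although its separation from compound 2, a 1.1-fold higher number from compound 2 to compound 3 (0.04 log units; within the scatter), lies within the scatter, so the two cannot be ordered. Compound 4, `COc1cc(-c2cc(/C=C/C(=O)c3ccc(F)c(F)c3)[nH]n2)cc(OC)c1OC`, differs from compound 3 by 3,4-difluorophenyl in place of 4-methoxyphenyl on a carbonyl carbon. The measured steps that bear on this change are the two that exchange a 3,4-dichlorophenyl for a methoxy-bearing phenyl on the same carbonyl carbon: an at least 38-fold lower number from compound 1 to compound 2 (1.59 log units; beyond the scatter) and an at least 35-fold lower number from compound 1 to compound 3 (1.54 log units; beyond the scatter), both large. The change to compound 4 runs the other way, from a 4-methoxyphenyl back to a 3,4-dihalogenated phenyl, and so a large upward step in this assay is expected, with the reservation that the halogen is now fluorine rather than chlorine, for which no direct comparison exists among these compounds. Compound 4 is therefore estimated at 30000 nM, with an expected range from 6000 nM to 150000 nM. That estimate would mean an 11-fold higher number from compound 3 to compound 4 (1.02 log units; beyond the scatter). A result reported only as the assay limit is also considered possible.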

Compound 4, concentration for total growth inhibition: 14200 nM
Estimate against measurement, compound 4: 2.1-fold (0.32 log units) above, and the stated range covers the measured number.
By their numbers in this assay, from the lowest: compounds 2 and 3 (each within the scatter of the next); then compound 4. At a limit, above all of these: compound 1.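

The 3,4-difluorophenyl group on the carbonyl carbon gives a higher number in this assay than either methoxy-bearing phenyl group, with a 5.0-fold higher number from compound 3 to compound 4 (0.70 log units; beyond the scatter) and a 5.5-fold higher number from compound 2 to compound 4 (0.74 log units; beyond the scatter), so the weaker inhibition of growth seen with 3,4-dichlorophenyl also appears, to a smaller degree, with a second dihalogenated phenyl. The two halogens can now be compared directly at this place, and the fluorine pair gives the stronger inhibition of growth, with an at least 7.0-fold lower number from compound 1 to compound 4 (0.84 log units; beyond the scatter). The size of that last step is only a bound, and compound 1 stands at a limit: the limit of > 100000 nM in this assay, at which 1 of the 4 values shown sits.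

The compounds shown leave open whether the higher numbers go with the halogens themselves or with the absence of a methoxy group, and an unsubstituted phenyl or a 4-fluorophenyl on the same carbonyl carbon would separate the two readings. As far as these compounds go, it also remains open where a phenyl carrying an amine or a carboxylic acid would fall, and how far compound 1 actually lies from compound 4.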